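The source may report more compounds than this note shows. Statements on the series, on what has been measured and on what is new or still open speak of the compounds shown alone.

Working notes on the series. Going by the values given here, compound 1 `COC1=C(OC)C(O)(CCn2cc(-c3ccccc3)nn2)NC1=O` and compound 2 `O=C1O/C(=C\Cn2cc(-c3ccccn3)nn2)C(OCc2ccccc2)=C1OCc1ccccc1` are the two compounds measured so far in a functional assay on U-937 cells (Homo sapiens) for antiproliferative activity, read by MTT assay, with a stated time of 24 h; a higher number here means a weaker inhibitor, a lower number a stronger inhibitor. In this assay compound 1 gives 20300 nM, while compound 2 gives 70200 nM; the gap between the two lies beyond the usual scatter, so compound 1 holds the lower number of the pair and is the stronger inhibitor of the two. Among the compounds with values here, no step between measured compounds that differ in only one place is available, so nothing tells how a single change shifts the read-out.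

Compound 3 `COC1=C(OC)C(O)(CCn2cc(-c3ccc(C(C)(C)C)cc3)nn2)NC1=O` is not yet measured. Relative to compound 1 it carries tert-butyl in place of hydrogen on an aromatic carbon. Within the data shown here, with no step of this kind to lean on, the expected change in this assay from compound 1 to compound 3 is estimated at a 1.7-fold lower number from compound 1 to compound 3 (0.23 log units; within the scatter), a shift toward a lower number but one that may still fall within the scatter. For compound 3 the half-maximal inhibitory concentration is therefore estimated at 12000 nM, with a range from 5000 nM to 40000 nM.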

Compound 3, half-maximal inhibitory concentration: > 100000 nM
Compound 3 gave a limit, no number; the forecaster's own chance of this, stated with the estimate: 10%; at least 8.3-fold (0.92 log units) between middle value and limit.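

Going by these compounds alone, this is the only step that changes one place: tert-butyl in place of hydrogen, on an aromatic carbon of a six-membered aromatic ring of carbon only, gives an at least 4.9-fold higher number from compound 1 to compound 3 (0.69 log units; beyond the scatter) in this assay. The earlier compounds shown here gave no reading of any single change, and this one shows that this carbon does not take the added tert-butyl without a move toward a weaker inhibitor. The step gives only a minimum size and rests on a limit, not a number: the limit of > 100000 nM in this assay, at which 1 of the 3 values shown sits.

The compounds shown leave open whether another group on this carbon, such as methyl, fluorine or an amine, would keep the read-out of compound 1. Nor do they tell whether tert-butyl on another carbon of that ring would give a step of this kind.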